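A few compounds are considered here, and "the series" means these few. Any claim that something is new, unique, unknown or untested is made for them only; others in the source may bear on it.

Measured compounds:
compound 1 `N=C(N)NCCC[C@H](NC(=O)CN(c1ncnc2c1ncn2C1CCCCO1)C1CC1)C(=O)OCc1ccccc1` — 52.4%
compound 2 `CC(C)C[C@H](NC(=O)CN(c1ncnc2c1ncn2C1CCCCO1)C1CC1)C(=O)OCc1ccccc1` — 34.2%

Going by the values given here, in a functional assay on the whole organism (Tail, strain ICR) with Mus musculus as the target, in the tail flick test, with a stated time of 60 min, at a dose of 25 umol/kg by the oral route (on this read-out higher numbers stand for a stronger effect at the one dose given and lower numbers for a weaker effect), compound 2 stands lowest of the two numbers; the only neighbour is compound 1, and the single measured step is a number 18.2 percentage points lower from compound 1 to compound 2 (beyond the scatter). That step is the only one in hand, and it bears on the present question only at the level of place: it changed the same saturated chain carbon, but exchanged a nitrogen-bearing group for a plain carbon group, whereas the change now considered keeps the size nearly constant and merely exchanges one uncharged group for another.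

Compound 3 `CSCC[C@H](NC(=O)CN(c1ncnc2c1ncn2C1CCCCO1)C1CC1)C(=O)OCc1ccccc1` differs from compound 2 by (methylsulfanyl)methyl in place of isopropyl on a saturated chain carbon, two bonds along the chain from an amide-type nitrogen and a carbonyl carbon. Among the compounds with values here, no measured pair shows an exchange of this kind, so the basis for a direction is thin. The expected step is a number 1.8 percentage points higher from compound 2 to compound 3 (within the scatter), which is not beyond the scatter. In this assay compound 3 is estimated at 36%, with a range from 20% to 52%.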

Compound 3, a percentage reported as activity, at one dose (the size of the read-out at that dose, not a potency): 41%
The estimate for compound 3 lay 5 percentage points below the measured number, and the stated range covers the measured number.
By their numbers in this assay, from the lowest: compounds 2 and 3 (each within the scatter of the next); then compound 1.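

In this assay, (methylsulfanyl)methyl in place of isopropyl on this saturated chain carbon gives a number 6.8 percentage points higher from compound 2 to compound 3 (within the scatter), so at this position the two uncharged side chains, of equal heavy-atom count, are not told apart by this read-out, even with sulfur in the chain. The nitrogen-bearing side chain of compound 1 now stands apart from two different uncharged side chains, with a number 11.4 percentage points lower from compound 1 to compound 3 (beyond the scatter) alongside a number 18.2 percentage points lower from compound 1 to compound 2 (beyond the scatter), and neither of the three compounds goes against this within so small a set. No measurement here speaks to the reason for either step.

As far as these compounds go, whether an amine, a carboxylic acid or a longer plain alkyl chain on this carbon would sit nearer compound 1 or nearer compound 2 and compound 3 remains open. Also open, from the compounds shown here alone, is whether the gap to compound 1 would persist with another ester in place of the benzyl ester.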